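Swapping the Aryl Ether for a Benzyl Group

A few compounds are considered here, and "the series" means these few. Any claim that something is new, unique, unknown or untested is made for them only; others in the source may bear on it.

Compound 1 `COc1ccc(Oc2ccc3c(NCCCNCc4cc(F)ccc4OC)ccnc3c2)cc1` gives 14500 nM in a physicochemical assay for solubility, with a stated time of 18 h, at pH 7.4; on this read-out higher numbers stand for higher solubility and lower numbers for lower solubility.
Compound 2 `CC(C)CCc1ccc2c(NCCCNCc3ccco3)ccnc2c1` gives 4200 nM in this assay.
Compound 3 `COc1ccc(Oc2ccc3c(NCCCNCc4ccco4)ccnc3c2)cc1` gives 14500 nM in this assay.

Compound 1 stands level with compound 3 at the digits shown, the two together the highest of the three, with compound 2 lowest. Compound 4 `COc1ccc(F)cc1CNCCCNc1ccnc2cc(Cc3ccccc3)ccc12` is not yet measured; it differs from compound 1 by benzyl in place of 4-methoxyphenoxy on an aromatic carbon. The step of no change at the digits printed from compound 1 to compound 3 (within the scatter) touches another site and gives no guidance here. The step of a 3.5-fold higher number from compound 2 to compound 3 (0.54 log units; beyond the scatter) is the one that bears on it, as it also exchanges the group on that aromatic carbon; since the group that enters in compound 4 has no hydrogen-bond acceptors, as in compound 2, a modest lowering is expected, a 2.6-fold lower number from compound 1 to compound 4 (0.42 log units; beyond the scatter). Compound 4 is estimated at 5500 nM, within 2500 nM to 12000 nM.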

Compound 4, solubility: 4200 nM
Estimate against measurement, compound 4: 1.3-fold (0.12 log units) above; measured number inside the range.
By their numbers in this assay, from the lowest: compounds 2 and 4 (each within the scatter of the next); then compounds 1 and 3 (each within the scatter of the next).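

Benzyl in place of 4-methoxyphenoxy on this aromatic carbon gives a 3.5-fold lower number from compound 1 to compound 4 (0.54 log units; beyond the scatter) in this assay, so a change at this position also moves the number when the 5-fluoro-2-methoxyphenyl group is present, not only with furan-2-yl. Benzyl keeps a six-membered aromatic ring of carbon only, yet that ring alone does not hold the number at the level of compound 1. Nothing available here explains this step. From the compounds shown here alone, it remains open whether an unsubstituted phenoxy or a morpholine at this carbon would keep the number of compound 1.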